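Swapping a hydroxymethyl for a hydroxyamino on the tail

The compounds below may be only part of what the source reports. "The series", "measured", "known", "first", "only" and "open" are said of these compounds alone.

Of the compounds shown here, two sharing one core have been measured so far. Compound 1 `OCc1ccc(CNc2cc(Br)cc3[nH]ncc23)cc1` is tested in an assay for inhibition of Indoleamine 2,3-dioxygenase 1 (Homo sapiens), with a stated time of 1 h, tested at 10 uM (on this read-out lower numbers stand for less inhibition and higher numbers for more inhibition at the one concentration tested (going by the name of the read-out)), where compound 1 gives 45%. Compound 2 `Nc1cccc(CNc2cc(Br)cc3[nH]ncc23)c1` in this assay gives 31%. Of these two numbers compound 1 stands highest, and its gap to compound 2 is larger than the usual scatter of repeated measurements, so the two can be told apart.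

Compound 3 `ONc1ccc(CNc2cc(Br)cc3[nH]ncc23)cc1` has not been measured yet. It comes from compound 1 by one change: hydroxyamino in place of hydroxymethyl on an aromatic carbon. The hydroxyamino group keeps the oxygen and the two-heavy-atom size of the group it replaces, so no large shift is expected. In this assay compound 3 is expected to give 40%, most likely between 20% and 60%. That estimate means an expected step of a number 5 percentage points lower from compound 1 to compound 3 (within the scatter) of no size beyond the scatter.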

Compound 3, a percentage reported as inhibition, at one concentration (the size of the read-out at that concentration, not a potency): "not active" (no number reported)
The entry for compound 3 holds no number, and the estimate cannot be compared.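

Among these compounds, compound 3 carries only the words "not active" and no number, so no step from compound 1 to compound 3 can be read. On these data alone, how far hydroxyamino in place of hydroxymethyl lowers inhibition, if it does, stays open. No supporting measurement bears on this result.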